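A methyl on the anilide phenyl of compound 2

The source may report more compounds than this note shows. Statements on the series, on what has been measured and on what is new or still open speak of the compounds shown alone.

Three compounds of the shared core have numbers in a functional assay on A-375 cells (Homo sapiens) for antiproliferative activity, read by MTT assay, with a stated time of 48 h; on this read-out lower numbers stand for stronger inhibition and higher numbers for weaker inhibition:

compound 1, `Nc1nc(CC2CCCC2)c(-c2ccccc2Br)n1CC(=O)Nc1ccccc1`, compound 1 gives 24300 nM
compound 2, `Nc1nc(Cc2ccccc2)c(-c2ccccc2Br)n1CC(=O)Nc1ccccc1`, compound 2 gives 5200 nM
compound 3, `Cc1ccc(Cc2nc(N)n(CC(=O)Nc3ccccc3)c2-c2ccccc2Br)cc1`, compound 3 gives 2500 nM

Compound 2 stands second highest of the three numbers. Its nearest neighbour is compound 3, reached by a 2.1-fold lower number from compound 2 to compound 3 (0.32 log units; beyond the scatter); its furthest is compound 1, from which a 4.7-fold lower number from compound 1 to compound 2 (0.67 log units; beyond the scatter) leads down to it. The step followed here is methyl in place of hydrogen on an aromatic carbon, which turns compound 2 into compound 4, `Cc1ccc(NC(=O)Cn2c(N)nc(Cc3ccccc3)c2-c2ccccc2Br)cc1`.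

Within the data shown here, only one measured step adds a methyl: a 2.1-fold lower number from compound 2 to compound 3 (0.32 log units; beyond the scatter). There, however, the methyl entered the phenyl on the saturated chain carbon bound to an aromatic carbon, whereas in compound 4 it enters the phenyl of the phenylcarbamoyl group. The steps of a 4.7-fold lower number from compound 1 to compound 2 (0.67 log units; beyond the scatter) and a 9.7-fold lower number from compound 1 to compound 3 (0.99 log units; beyond the scatter) change that same saturated chain carbon and do not speak to the phenylcarbamoyl group at all. Among the measured compounds shown here, nothing measured therefore bears directly on this change; the one methyl step is modest and at a different group. A small step downward, or none beyond the scatter, is expected: a 1.4-fold lower number from compound 2 to compound 4 (0.14 log units; within the scatter) is the estimate. Compound 4 is accordingly expected to give 3800 nM, within 1500 nM to 9000 nM.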

Compound 4, half-maximal inhibitory concentration: 2000 nM
Compound 4: middle estimate off by 1.9-fold (0.28 log units), on the high side; the measured number falls inside the stated range.
By their numbers in this assay, from the lowest: compounds 4 and 3 (each within the scatter of the next); then compound 2; then compound 1.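

In this assay, among these compounds, the phenylcarbamoyl group of compound 2, on which the earlier compounds said nothing, turns out to respond to substitution: the change to (4-methylphenyl)carbamoyl gives a 2.6-fold lower number from compound 2 to compound 4 (0.41 log units; beyond the scatter), a modest step but a real one. Read beside a 2.1-fold lower number from compound 2 to compound 3 (0.32 log units; beyond the scatter), it means that methyl in place of hydrogen has now lowered the number at two separate phenyl groups of compound 2, and no compound shown goes against this, though the pattern rests on those two steps alone. No measured evidence is available to explain why the number falls at this position.

On these data alone, what remains open is whether the lower number belongs to the methyl itself or would also follow other groups on that aromatic carbon, such as chloro, methoxy or a carboxylic acid, and whether a methyl on another carbon of the same phenyl would do the same. Also open, as far as these compounds go, is whether the two methyl groups, placed together in one compound on the shared core, would lower the number further.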